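The source may hold more compounds than are shown below. What is called first, only, known or untested is meant among the compounds shown, and "the series" means these compounds.

In a functional assay on HCT-116 cells (Homo sapiens) for antiproliferative activity, read by MTT assay, with a stated time of 72 h (a lower number here means a stronger inhibitor, a higher number a weaker inhibitor), compound 1 `O=C(CCc1cccc2c1B(O)OC2)Nc1cccc(-c2cccc(F)c2)c1` gives 460 nM and compound 2 `O=C(CCc1cccc2c1B(O)OC2)Nc1cccc(-c2cccc(OC(F)(F)F)c2)c1` gives 310 nM, so the two lie within the scatter of each other. Compound 3 `CSc1ccc(-c2cccc(NC(=O)CCc3cccc4c3B(O)OC4)c2)cc1` is still unmeasured. Its difference from compound 1 is 4-(methylsulfanyl)phenyl in place of 3-fluorophenyl on an aromatic carbon. For the measured compounds named here, the one measured step, a 1.5-fold lower number from compound 1 to compound 2 (0.17 log units; within the scatter), put trifluoromethoxy in place of fluoro and stayed within the scatter. Going by the values given here, no measured compound carries the entering group, so no shift beyond the scatter is expected in this assay. The expected step is a 1.2-fold lower number from compound 1 to compound 3 (0.06 log units; within the scatter). The estimate for compound 3 is 400 nM, with an expected range of 150 nM to 1100 nM.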

Compound 3, half-maximal inhibitory concentration: 180 nM
Estimate against measurement, compound 3: 2.2-fold (0.35 log units) above, within the range that was stated.
By their numbers in this assay, from the lowest: compounds 3, 2 and 1 (each within the scatter of the next, the first and the last beyond it).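

In this assay, for the compounds shown here, 4-(methylsulfanyl)phenyl in place of 3-fluorophenyl gives a 2.6-fold lower number from compound 1 to compound 3 (0.41 log units; beyond the scatter) and is the first step beyond the scatter, so activity does respond to the aryl group at this place. The step changes both the substituent and where it sits on the ring, and it cannot separate the two. Nothing on hand explains the shift.

Open, as far as these compounds go, is whether 3-(methylsulfanyl)phenyl or 4-methoxyphenyl would keep the shift. Also open, from the compounds shown here alone, is how an amine or a carboxylic acid on this ring would read.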